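Swapping 4-nitrophenyl for 3,4-difluorophenyl on the Ring Amine

The compounds below may be only part of what the source reports. "The series", "measured", "known", "first", "only" and "open" are said of these compounds alone.

Compound 1: `Nc1scc(CN2CCN(c3ccc([N+](=O)[O-])cc3)CC2)c1C(=O)c1ccc(Cl)cc1` — -17%
Compound 2: `Nc1scc(CN2CCN(c3cccnc3)CC2)c1C(=O)c1ccc(Cl)cc1` — -23%
Compound 3: `Nc1scc(CN2CCN(c3ccc(C(F)(F)F)cc3)CC2)c1C(=O)c1cccc(C(F)(F)F)c1` — -47%

These three compounds were measured in a functional assay on CHO cells with adenosine receptor A1 (Homo sapiens) as the target, read by cAMP accumulation and immunoassay, with a stated time of 6 min, tested at 10 uM; a higher number here means a weaker effect of the compound at the concentration tested, a lower number a stronger effect. Compound 1 holds the highest of the three numbers; compound 2 sits nearest, the step of a number 6 percentage points lower from compound 1 to compound 2 (within the scatter) being within the scatter, while compound 3 lies furthest, and the gap between compound 1 and compound 3 is beyond the scatter. Compound 3 differs from compound 1 in two places at once, so its value alone says little about either change.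

The compound still to be measured is compound 4, `Nc1scc(CN2CCN(c3ccc(F)c(F)c3)CC2)c1C(=O)c1ccc(Cl)cc1`. It differs from compound 1 by 3,4-difluorophenyl in place of 4-nitrophenyl on an amine nitrogen in a ring. Going by the values given here, the one measured step that bears on this change is that from compound 1 to compound 2, where the same 4-nitrophenyl was replaced on the same amine nitrogen in a ring and the number moved only a number 6 percentage points lower from compound 1 to compound 2 (within the scatter), within the scatter. On that basis a step of no size beyond the scatter is expected for compound 4, that is a number 3 percentage points lower from compound 1 to compound 4 (within the scatter). Compound 4 is therefore estimated at -20%, in a range from -42% to 2%.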

Compound 4, a percentage reported as activity, at one concentration (the size of the read-out at that concentration, not a potency): -87%
The estimate for compound 4 lay 67 percentage points above the measured number; measured number below the stated range.
By their numbers in this assay, from the lowest: compound 4; then compound 3; then compounds 2 and 1 (each within the scatter of the next).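

In this assay, going by these compounds alone, the substituent on this amine nitrogen proved able to shift the read-out strongly: placing 3,4-difluorophenyl on it gives a number 70 percentage points lower from compound 1 to compound 4 (beyond the scatter) and a number 64 percentage points lower from compound 2 to compound 4 (beyond the scatter), whereas the only earlier step at this place, a number 6 percentage points lower from compound 1 to compound 2 (within the scatter), had suggested a position that tolerates exchange with little effect. With the rest of the molecule unchanged, 3,4-difluorophenyl thus gives a clearly stronger effect at the concentration tested than either 4-nitrophenyl or pyridin-3-yl, so the similar values of those two groups do not describe the position as a whole. Nothing available here accounts for the difference between 3,4-difluorophenyl and the two groups it replaced.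

The compounds shown leave open whether both fluorines are needed, which a phenyl carrying a single fluorine or an unsubstituted phenyl would address, and whether chlorine could take the place of fluorine. They also leave open how much of the value of compound 3 comes from the trifluoromethyl on the phenyl at this nitrogen, since that compound also differs from the others at its second aryl group.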